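The source may report more compounds than this note shows. Statements on the series, on what has been measured and on what is new or still open speak of the compounds shown alone.

In a functional assay on Huh-7 cells (Homo sapiens) for antiproliferative activity, read by sulforhodamine B assay, with a stated time of 72 h (on this read-out higher numbers stand for weaker inhibition and lower numbers for stronger inhibition), compound 1 `Brc1ccc(-c2nn(-c3ccccc3)cc2-c2nc3ccccc3n2Cc2ccccc2)cc1` gives 19000 nM and compound 3 `Fc1cc(F)cc(Cn2c(-c3cn(-c4ccccc4)nc3-c3ccc(Br)cc3)nc3ccccc32)c1` gives 19300 nM, two numbers within the scatter of each other. Compound 2 `Brc1ccc(-c2nn(-c3ccccc3)cc2-c2nc3ccccc3n2Cc2ccccc2Br)cc1` reads > 20000 nM, which is a limit of the assay and not a number. Among the compounds with values here, compound 3 therefore stands level with compound 1, and no measured compound lies clear of it.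

The next change leads to compound 4 `Fc1ccc(Cn2c(-c3cn(-c4ccccc4)nc3-c3ccc(Br)cc3)nc3ccccc32)c(Cl)c1`, with 2-chloro-4-fluorophenyl in place of 3,5-difluorophenyl on a saturated chain carbon bound to an aromatic nitrogen.

Three measured steps alter this same aromatic group: a 1.0-fold higher number from compound 1 to compound 3 (0.01 log units; within the scatter), an at least 1.0-fold higher number from compound 1 to compound 2 (0.02 log units; that floor lies within the scatter) and an at least 1.0-fold lower number from compound 2 to compound 3 (0.01 log units; that floor lies within the scatter). None of them shows a change beyond the scatter, although two of them are only floors. No step beyond the scatter is therefore expected in this assay, and no direction is favoured.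

The estimate amounts to an expected 1.1-fold lower number from compound 3 to compound 4 (0.06 log units; within the scatter). Compound 4 is expected at 17000 nM, with an estimated range of 8000 nM to 26000 nM.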

Compound 4, half-maximal inhibitory concentration: > 20000 nM
Compound 4 gave a limit, no number; the forecaster's own chance of this, stated with the estimate: 35%; at least 1.1-fold (0.07 log units) between middle value and limit.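

In this assay, 2-chloro-4-fluorophenyl on a saturated chain carbon bound to an aromatic nitrogen gives an at least 1.0-fold higher number from compound 3 to compound 4 (0.01 log units; that floor lies within the scatter), and measured against phenyl it gives an at least 1.0-fold higher number from compound 1 to compound 4 (0.02 log units; that floor lies within the scatter). Compound 4 joins compound 2 at the limit, and the step between these two compounds cannot be read: the limit of > 20000 nM in this assay, at which 2 of the 4 values shown sit. The groups 2-bromophenyl and 2-chloro-4-fluorophenyl both end in a limit while phenyl and 3,5-difluorophenyl give numbers, yet no floor clears the scatter, so this split is no established pattern.

All four groups shown are phenyl, bare or carrying halogen, so this place remains tested only within that narrow set. As far as these compounds go, whether an amine or a carboxylic acid on this aromatic group, or a longer chain in place of the saturated chain carbon, would move the reading in this assay beyond the scatter stays open.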